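This account rests on a few compounds, and the source may have more. Where it says the series, first, only, none or still open, it means among the compounds named here.

Measured compounds:
- compound 1 `NC(=O)/C=C/c1ccncc1-c1ccc2ccccc2c1`, in a functional assay on MDA-MB-231 cells (Homo sapiens) for inhibition, read by sulforhodamine B assay, with a stated time of 72 h; on this read-out higher numbers stand for weaker inhibition of growth and lower numbers for stronger inhibition of growth: > 10000 nM, a limit of the assay
- compound 2 `COC1CN(C(=O)/C=C/c2ccncc2-c2ccc3ccccc3c2)C1`, in this assay: > 10000 nM, a limit of the assay
- compound 3 `O=C(O)/C=C/c1ccncc1-c1ccc2ccccc2c1`, in this assay: > 10000 nM, a limit of the assay

Compound 3 stands where every value in this set stands: at the limit of > 10000 nM in this assay, at which 3 of the 3 values shown sit. Going by the values given here, no compound here has a number, so compound 3 can be placed neither above nor below the other two. The three steps among the measured compounds, a step that the two limits leave unreadable from compound 1 to compound 2, a step that the two limits leave unreadable from compound 1 to compound 3 and a step that the two limits leave unreadable from compound 2 to compound 3, are all unreadable, since both ends of each sit at the limit.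

Compound 4 `O=C(/C=C/c1ccncc1-c1ccc2ccccc2c1)N1CCOCC1` differs from compound 3 by morpholin-4-yl in place of hydroxy on a carbonyl carbon. The exchanges at the same carbonyl carbon that have been measured, from hydroxy to amino to 3-methoxyazetidin-1-yl, all left the read-out at the limit, so no size can be assigned to them, and no step beyond the scatter is expected in this assay in either direction. Compound 4 is expected at 10000 nM, with a range from 3000 nM to 30000 nM, most probably reported again only as a limit. The step that this estimate means is expected to be a number no higher from compound 3 to compound 4 (the limit leaves the size open).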

Compound 4, concentration for 50% growth inhibition: 8980 nM
For compound 4 the middle estimate is 1.1-fold (0.05 log units) above the measured one, within the range that was stated.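

At the carbonyl carbon, morpholin-4-yl gives the first read-out in this assay that is a number and not a limit, so this position now has one measured point. The change can be read only as a floor, an at least 1.1-fold lower number from compound 3 to compound 4 (0.04 log units; that floor lies within the scatter), an at least 1.1-fold lower number from compound 2 to compound 4 (0.04 log units; that floor lies within the scatter) and an at least 1.1-fold lower number from compound 1 to compound 4 (0.04 log units; that floor lies within the scatter), so it cannot yet be called a gain beyond the scatter. Compound 4 alone carries a number, and the rest of the set still rests on one limit: the limit of > 10000 nM in this assay, at which 3 of the 4 values shown sit.

From the compounds shown here alone, the true values of compound 1, compound 2 and compound 3 stay open, so the steps among those three cannot be read and the full size of the steps to compound 4 is unknown. Also open, going by these compounds, is what the ring oxygen of morpholin-4-yl contributes, which a piperidin-1-yl or a 4-methylpiperazin-1-yl on the same carbonyl carbon would test.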